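Trifluoromethyl on the benzyl ring of compound 3

This account rests on a few compounds, and the source may have more. Where it says the series, first, only, none or still open, it means among the compounds named here.

Compound 1 (`O=[N+]([O-])c1ccc(COc2ccc(Nc3ncnc4cc5c(cc34)OCCOCCO5)cc2)cc1`) gives a number of 39700 nM
Compound 2 (`FC(F)(F)c1ccc(COc2ccccc2Nc2ncnc3cc4c(cc23)OCCOCCO4)cc1`) gives a limit of > 100000 nM
Compound 3 (`c1ccc(COc2ccc(Nc3ncnc4cc5c(cc34)OCCOCCO5)cc2)cc1`) gives a limit of > 100000 nM

In a functional assay on MCF7 cells (Homo sapiens) for antiproliferative activity, read by MTT assay, with a stated time of 72 h (on this read-out lower numbers stand for stronger inhibition and higher numbers for weaker inhibition), compound 3 gives only a limit and no number (> 100000 nM), and one further compound shares this limit (the limit of > 100000 nM in this assay, at which 2 of the 3 values shown sit). The step to compound 4 (`FC(F)(F)c1ccc(COc2ccc(Nc3ncnc4cc5c(cc34)OCCOCCO5)cc2)cc1`) is trifluoromethyl in place of hydrogen on an aromatic carbon (trifluoromethyl in place of hydrogen on an aromatic carbon, para to a large group).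

Among the measured compounds shown here, one measured step bears on this change directly: an at least 2.5-fold higher number from compound 1 to compound 3 (0.40 log units; beyond the scatter) (hydrogen in place of nitro on an aromatic carbon). Read backwards, it shows a group on that same aromatic carbon going with a lower number, but it is modest and rests on a single pair. Compound 2 carries the same 4-(trifluoromethyl)benzyl group, and its value is a limit (> 100000 nM). It therefore offers no sign of a gain from that group.

On the strength of compound 1 (39700 nM), a modest move toward stronger inhibition is expected, of the estimated size an at least 1.6-fold lower number from compound 3 to compound 4 (0.22 log units; that floor lies within the scatter) in the direction of a lower number. The assay may again report only a limit. The estimated value for compound 4 is 60000 nM with an expected range from 20000 nM to 100000 nM as its bounds.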

Compound 4, half-maximal inhibitory concentration: > 100000 nM
Compound 4: no number, only a limit; the forecaster's own chance of this, stated with the estimate: 45%; at least 1.6-fold (0.22 log units) between middle value and limit.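

In this assay compound 4 gives only a limit, > 100000 nM, so trifluoromethyl on this aromatic carbon, para to a large group, yields no readable number, and the step from hydrogen cannot be read. The comparison with nitro can be read: trifluoromethyl in place of nitro gives an at least 2.5-fold higher number from compound 1 to compound 4 (0.40 log units; beyond the scatter), which shows that a group on this carbon does not in itself go with a lower number, something the hydrogen-for-nitro step alone could not show. Nitro is thus the only group at this position with a number so far, and most of the series gives only a limit: the limit of > 100000 nM in this assay, at which 3 of the 4 values shown sit.

Open, from the compounds shown here alone, is whether a nitrile, a carboxylic acid or an amine on this same aromatic carbon would give a readable number, and how such a number would compare with that of compound 1, 39700 nM. Also open, going by these compounds, is whether the readable value belongs to nitro more generally, as that link rests on compound 1 alone.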